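Triazole Substituent Exchange and Cytotoxicity in HEK293 Cells

A few compounds are considered here, and "the series" means these few. Any claim that something is new, unique, unknown or untested is made for them only; others in the source may bear on it.

Measured compounds:
Compound 1, `COc1nc2ccc(Br)cc2cc1C(c1ccccc1)n1cc(-c2ccccc2)nn1`, 8.25%
Compound 2, `COc1nc2ccc(Br)cc2cc1C(c1ccccc1)n1cc(-c2ccc(OC(F)(F)F)cc2)nn1`, 5.8%
Compound 3, `COc1nc2ccc(Br)cc2cc1C(c1ccccc1)n1cc(-c2ccc(F)cc2)nn1`, 4.04%

The three compounds were tested in an ADME assay on HEK293 cells (Homo sapiens) for cytotoxicity, read by sulforhodamine B assay, with a stated time of 48 h, tested at 10 uM; a lower number here means less inhibition, a higher number more inhibition at the concentration tested (going by the name of the read-out). Compound 3 gives the lowest of the three numbers, but its neighbours lie close: a number 1.8 percentage points lower from compound 2 to compound 3 (within the scatter), and a number 4.2 percentage points lower from compound 1 to compound 3 (within the scatter). The third pair is no different: a number 2.5 percentage points lower from compound 1 to compound 2 (within the scatter). All three share the same core and differ only in the group on the phenyl ring attached to the five-membered aromatic ring, and every exchange among them left the read-out essentially where it was.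

Compound 4, `COc1nc2ccc(Br)cc2cc1C(c1ccccc1)n1cc(CCCCCO)nn1`, replaces that phenyl ring altogether: 5-hydroxypentyl in place of 4-fluorophenyl on an aromatic carbon. Within the data shown here, no measured step removes the aromatic ring or introduces a chain carrying a hydroxyl, so the measured steps bear on the question only in that each change at this position, whatever its size, stayed within the scatter. On that basis, and because the starting point 4.04% of compound 3 is already low, the step from compound 3 to compound 4 is expected to be a number 2 percentage points higher from compound 3 to compound 4 (within the scatter), that is, nothing beyond the scatter. Compound 4 is thus estimated at 6%, within a range from 0% to 16%.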

Compound 4, a percentage reported as inhibition, at one concentration (the size of the read-out at that concentration, not a potency): 7.96%
Compound 4: middle estimate off by 2 percentage points, on the low side; low and high end bracket the measured number.
By their numbers in this assay, from the lowest: compounds 3, 2, 4 and 1 (each within the scatter of the next).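

The earlier compounds shown here varied only a group on the phenyl ring, whereas compound 4 removes that aromatic ring altogether and puts a ringless chain carrying a hydroxyl on the same aromatic carbon. Even so, in this assay the exchange stays small against each of the three aryl compounds: a number 3.9 percentage points higher from compound 3 to compound 4 (within the scatter) and a number 2.2 percentage points higher from compound 2 to compound 4 (within the scatter) and a number 0.3 percentage points lower from compound 1 to compound 4 (within the scatter). At this position, then, the read-out does not separate 5-hydroxypentyl from phenyl, 4-fluorophenyl or 4-(trifluoromethoxy)phenyl, and nothing available offers an explanation for this.

On these data alone, all four compounds give low numbers at a single concentration, so it remains open whether any group at this place would move the read-out beyond the scatter, such as an amine, a carboxylic acid or a longer chain. The four also share the same core, which leaves open whether the same indifference would hold if the bromine or the methoxy group on that core were replaced, for instance by chlorine or by an ethoxy group.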